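A few compounds are considered here, and "the series" means these few. Any claim that something is new, unique, unknown or untested is made for them only; others in the source may bear on it.

Measured so far:
Compound 1, `O=C(/C=C\Nc1ccc(Cl)cc1)c1cn(-c2ccccc2)nc1-c1ccc(F)cc1`: 8900 nM
Compound 2, `COc1cc(N/C=C\C(=O)c2cn(-c3ccccc3)nc2-c2ccc(Cl)cc2)cc(OC)c1OC`: 17800 nM

Both numbers come from a functional assay on U-87MG ATCC cells (Homo sapiens) for antiproliferative activity, read by MTT assay, with a stated time of 48 h; on this read-out lower numbers stand for stronger inhibition and higher numbers for weaker inhibition. Compound 1 gives 8900 nM, and compound 2 gives 17800 nM. These two values lie within the usual scatter of each other, so on this read-out compound 2 cannot be told apart from compound 1, and neither can be called the more or less potent of the pair.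

Compound 3, `COc1cc(N/C=C\C(=O)c2cn(-c3ccccc3)nc2-c2cc(OC)c(OC)c(OC)c2)cc(OC)c1OC`, has not yet been measured. It differs from compound 2 in one place: 3,4,5-trimethoxyphenyl in place of 4-chlorophenyl on an aromatic carbon. For the measured compounds named here, no pair of measured compounds shows what this change does, so the expectation for compound 3 rests on the value of compound 2 alone and on the size of the change itself. A step beyond the scatter toward a lower number is expected in this assay, of the size a 5.1-fold lower number from compound 2 to compound 3 (0.71 log units; beyond the scatter), though a result within the scatter would not be surprising.

Compound 3 is estimated at 3500 nM, within a range of 600 nM to 18000 nM.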

Compound 3, half-maximal inhibitory concentration: 5100 nM
Beside the measured number, compound 3's estimate is 1.5-fold (0.16 log units) below it; measured number inside the range.
By their numbers in this assay, from the lowest: compounds 3, 1 and 2 (each within the scatter of the next, the first and the last beyond it).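

On the aromatic carbon of the five-membered ring, next to the ring nitrogen, 3,4,5-trimethoxyphenyl in place of 4-chlorophenyl gives in this assay a 3.5-fold lower number from compound 2 to compound 3 (0.54 log units; beyond the scatter). This is the first step shown at this position, and although modest, it lies beyond the scatter, so the group carried here can shift the read-out, and the entering group, with more heavy atoms and with oxygen in place of chlorine, brings no loss of antiproliferative activity. Nothing measured here accounts for the step.

The step replaces the whole substituted ring in one move, so the compounds shown cannot separate what leaving chlorine contributes from what the methoxy groups contribute, or tell whether all of those methoxy groups are needed. A plain phenyl or a 4-methoxyphenyl at this position would begin to divide the change into its parts, while a 4-aminophenyl would show how a ring bearing an amine compares with these two groups.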